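This account rests on a few compounds, and the source may have more. Where it says the series, first, only, none or still open, it means among the compounds named here.

Three compounds of the series have numbers in a functional assay on CCRF-CEM cells (Homo sapiens), read by MTT assay, with a stated time of 3 days; on this read-out lower numbers stand for stronger inhibition and higher numbers for weaker inhibition. Compound 1 `CNc1ncnc2[nH]cc(Sc3cccs3)c12` gives 14700 nM; compound 2 `Nc1ncnc2[nH]cc(Sc3cccs3)c12` gives 16700 nM; compound 3 `c1csc(Sc2c[nH]c3ncnc(-c4cccs4)c23)c1` gives 10600 nM. Compound 3 has the lowest of the three numbers, but its steps to the other two are within the scatter: a 1.4-fold lower number from compound 1 to compound 3 (0.14 log units; within the scatter) and a 1.6-fold lower number from compound 2 to compound 3 (0.20 log units; within the scatter). Likewise a 1.1-fold higher number from compound 1 to compound 2 (0.06 log units; within the scatter).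

Compound 4 `COc1ncnc2[nH]cc(Sc3cccs3)c12` is not yet measured in this assay. It differs from compound 3 at one place: methoxy in place of thiophen-2-yl on an aromatic carbon. The steps from compound 1 to compound 3 and from compound 2 to compound 3 bear on this change, since each exchanges the group on the same aromatic carbon of the shared core, and neither moved the number beyond the scatter. With methoxy entering in place of thiophen-2-yl, no step beyond the scatter is expected from compound 3 to compound 4; the estimated step is a 1.2-fold higher number from compound 3 to compound 4 (0.09 log units; within the scatter). Compound 4 is therefore expected to give 13000 nM, with a range from 6000 nM to 30000 nM.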

Compound 4, half-maximal inhibitory concentration: 18200 nM
Beside the measured number, compound 4's estimate is 1.4-fold (0.15 log units) below it; the measured number falls inside the stated range.
By their numbers in this assay, from the lowest: compounds 3, 1, 2 and 4 (each within the scatter of the next).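

Methoxy on this aromatic carbon extends the flat picture: in this assay the exchange for thiophen-2-yl stays within the scatter (a 1.7-fold higher number from compound 3 to compound 4 (0.23 log units; within the scatter)), even though a group of 5 heavy atoms with a five-membered aromatic ring gives way to one of 2 heavy atoms with no ring. The exchanges for amino (a 1.1-fold higher number from compound 2 to compound 4 (0.04 log units; within the scatter)) and for methylamino (a 1.2-fold higher number from compound 1 to compound 4 (0.09 log units; within the scatter)) also stay within the scatter, so these four groups on this carbon cannot be told apart on this read-out. No measurement at hand offers an explanation for this flatness.

On these data alone, whether a carboxylic acid, a longer chain or a larger amine on this carbon would move the number beyond the scatter stays open. Also open, as far as these compounds go, is whether the picture holds once the sulfur-linked thiophene on the shared core is replaced.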